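Swapping the amine tail for a hydroxyalkyl chain

A few compounds are considered here, and "the series" means these few. Any claim that something is new, unique, unknown or untested is made for them only; others in the source may bear on it.

Measured compounds:
- Compound 1, `CCCCSS[C@H]1C[C@H](n2cc(C)c(=O)[nH]c2=O)O[C@@H]1CO`: 28000 nM
- Compound 2, `CCCCCCCCSS[C@H]1C[C@H](n2cc(C)c(=O)[nH]c2=O)O[C@@H]1CO`: 26000 nM
- Compound 3, `Cc1cn([C@H]2C[C@H](SSCCN)[C@@H](CO)O2)c(=O)[nH]c1=O`: 163000 nM

All three share the same core and differ only in the chain hanging from the disulfide. In a functional assay on MOLT-4 cells (Homo sapiens) for cytotoxicity (a higher number here means a weaker inhibitor, a lower number a stronger inhibitor), compound 3 gives the highest number of the three, with compound 1 the nearest to it and compound 2 the furthest. Compound 4, `Cc1cn([C@H]2C[C@H](SSCCCCCCO)[C@@H](CO)O2)c(=O)[nH]c1=O`, has not yet been measured; it differs from compound 3 in that (4-hydroxybutyl in place of amino on a saturated chain carbon, two bonds along the chain from a sulfur).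

Two of the measured steps bear directly on this change, since both exchange an alkyl chain for the amino tail at the same place. The step of a 5.8-fold higher number from compound 1 to compound 3 (0.77 log units; beyond the scatter) and the step of a 6.3-fold higher number from compound 2 to compound 3 (0.80 log units; beyond the scatter) both point the same way: the amino tail goes with a clearly higher number than a plain chain. By contrast a 1.1-fold lower number from compound 1 to compound 2 (0.03 log units; within the scatter), so lengthening the chain itself made no difference beyond the scatter. Compound 4 carries a chain ending in a hydroxyl rather than an amine, so the amino tail is removed and a longer chain enters. For the measured compounds named here, the expected outcome is therefore a lower number, roughly undoing the step seen from compound 1 to compound 3, though the terminal hydroxyl has no measured precedent here and widens the uncertainty. For compound 4 the estimated step is a 4.1-fold lower number from compound 3 to compound 4 (0.61 log units; beyond the scatter), giving an expected value of 40000 nM with a range from 15000 nM to 120000 nM.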

Compound 4, half-maximal inhibitory concentration: 42000 nM
Beside the measured number, compound 4's estimate is 1.1-fold (0.02 log units) below it; the measured number falls inside the stated range.
By their numbers in this assay, from the lowest: compounds 2, 1 and 4 (each within the scatter of the next); then compound 3.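

In this assay, the step of a 3.9-fold lower number from compound 3 to compound 4 (0.59 log units; beyond the scatter) shows that the higher number seen with compound 3 does not carry over to every chain with a group at its far end: here, 4-hydroxybutyl replaces amino on a saturated chain carbon, two bonds along the chain from a sulfur. The hydroxyl-ended chain also reads the same as the plain alkyl chains, with a 1.6-fold higher number from compound 2 to compound 4 (0.21 log units; within the scatter) and a 1.5-fold higher number from compound 1 to compound 4 (0.18 log units; within the scatter), so among these four compounds only compound 3, with its amino tail, stands apart. Nothing available here accounts for why the amino tail stands apart or why the hydroxyl-ended chain does not.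

Compound 3 has both a short chain and an amine, so the compounds shown leave open whether the amine alone goes with the higher number, a question that a 6-aminohexyl chain and a 2-hydroxyethyl chain on the same disulfide could help to settle. They also leave open whether a carboxylic acid at the end of the chain would read like the hydroxyl of compound 4 or the amine of compound 3.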